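Half-life of compound 3 after the ring gives way to an amide

The source may hold more compounds than are shown below. What is called first, only, known or untested is meant among the compounds shown, and "the series" means these compounds.

Measured in an ADME assay on microsomes from liver (Rattus norvegicus) for metabolic stability; a lower number here means that the compound disappears faster, a higher number that the compound lasts longer:
- compound 1 `CC(C)C(Cc1noc(=O)[nH]1)c1ccc(-c2ccc3cccc(F)c3c2)[nH]c1=O`: > 3 h, a limit of the assay
- compound 2 `CC(C)C(c1ccc(-c2ccc3cccc(F)c3c2)[nH]c1=O)N1CCNC1=O`: 0.283 h

Within the data shown here, compound 2 gives the only actual number so far, 0.283 h. For compound 1, the result is the limit of > 3 h in this assay, at which 1 of the 2 values shown sits. Compound 3 `CC(C)NC(=O)CC(c1ccc(-c2ccc3cccc(F)c3c2)[nH]c1=O)C(C)C` carries (isopropylcarbamoyl)methyl in place of 2-oxoimidazolidin-1-yl on a saturated chain carbon bound to an aromatic carbon and a saturated chain carbon, that is, (isopropylcarbamoyl)methyl in place of 2-oxoimidazolidin-1-yl on a saturated chain carbon bound to an aromatic carbon and a saturated chain carbon. Among the measured compounds shown here, the one measured step at this place is large, an at least 10-fold lower number from compound 1 to compound 2 (1.02 log units; beyond the scatter), so a change here can matter, but that step does not involve the entering group. Only a small rise, perhaps within the scatter, is therefore expected, a 1.8-fold higher number from compound 2 to compound 3 (0.25 log units; within the scatter). In this assay, compound 3 is estimated at 0.5 h, with an expected range from 0.15 h to 1.5 h.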

Compound 3, half-life: < 0.0667 h
Compound 3: only a limit was reported; the forecaster's own chance of this, stated with the estimate: 5%; middle value at least 7.4-fold (0.87 log units) from the limit.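

In this assay, the open-chain (isopropylcarbamoyl)methyl group at this saturated chain carbon gives an at least 4.2-fold lower number from compound 2 to compound 3 (0.62 log units; beyond the scatter), and the comparison with the oxadiazolone-bearing side chain gives an at least 44-fold lower number from compound 1 to compound 3 (1.65 log units; beyond the scatter). Compound 3 therefore lies lowest of the three, so this position also responds strongly to a group with no ring. Compound 3 gives only a limit of the assay: the limit of < 0.0667 h in this assay, at which 1 of the 3 values shown sits.

The compounds shown leave open how large these steps really are, and whether the drop follows the amide or its isopropyl group. A primary amide or a carboxylic acid on the same chain could separate the two.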